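Replacing the isopropoxy group of compound 3

The compounds below may be only part of what the source reports. "The series", "measured", "known", "first", "only" and "open" are said of these compounds alone.

Measured compounds in a physicochemical assay for solubility, with a stated time of 24 h, tested at 30 mg/mL (on this read-out higher numbers stand for higher solubility and lower numbers for lower solubility), so far
- compound 1 `CC(=O)N1CC(CC(=O)NO)(NS(=O)(=O)c2ccc(OCc3cc(C)nc4ccccc34)cc2)C1` gives 800000 nM
- compound 2 `Cc1cc(COc2ccc(S(=O)(=O)NC3(CC(=O)NO)CN(C(=O)CC(C)C)C3)cc2)c2ccccc2n1` gives 900000 nM
- compound 3 `Cc1cc(COc2ccc(S(=O)(=O)NC3(CC(=O)NO)CN(C(=O)OC(C)C)C3)cc2)c2ccccc2n1` gives 1100000 nM

Compound 3 stands level with compound 1 and compound 2, since both of its steps to them lie within the scatter. Compound 4 `Cc1cc(COc2ccc(S(=O)(=O)NC3(CC(=O)NO)CN(C(=O)C(C)(C)N(C)C)C3)cc2)c2ccccc2n1` keeps the shared core and differs from compound 3 at one place: 1-(dimethylamino)-1-methylethyl in place of isopropoxy on a carbonyl carbon. In words, this is 1-(dimethylamino)-1-methylethyl in place of isopropoxy on a carbonyl carbon.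

The measured steps that bear on this change all sit on that same carbonyl carbon. Isopropoxy in place of methyl gave a 1.4-fold higher number from compound 1 to compound 3 (0.14 log units; within the scatter), and isopropoxy in place of isobutyl gave a 1.2-fold higher number from compound 2 to compound 3 (0.09 log units; within the scatter). The remaining step is a 1.1-fold higher number from compound 1 to compound 2 (0.05 log units; within the scatter). Going by the values given here, all three stay small, yet none of the measured compounds carries a dimethylamino group, so the data do not cover the entering group directly and the range has to stay wide. No move beyond the scatter is expected in this assay, and the estimated change is a 1.3-fold higher number from compound 3 to compound 4 (0.10 log units; within the scatter) in this account. The estimate is that compound 4 gives 1400000 nM, with 600000 nM to 5000000 nM as its expected range.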

Compound 4, solubility: 11000000 nM
Compound 4: the middle estimate sits 7.9-fold (0.90 log units) below what was measured, outside the stated range (above it).
By their numbers in this assay, from the lowest: compounds 1, 2 and 3 (each within the scatter of the next); then compound 4.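

In this assay, the carbonyl carbon bound to the amide-type nitrogen in a ring had seemed indifferent to what it carried, since methyl, isobutyl and isopropoxy all stayed within the scatter of one another, but 1-(dimethylamino)-1-methylethyl changes that picture (in place of isopropoxy, a 10-fold higher number from compound 3 to compound 4 (1.00 log units; beyond the scatter)). The rise appears from each of the other groups, with the same entering group in place of isobutyl giving a 12-fold higher number from compound 2 to compound 4 (1.09 log units; beyond the scatter) and in place of methyl giving a 14-fold higher number from compound 1 to compound 4 (1.14 log units; beyond the scatter), so among the compounds shown this position responds only to 1-(dimethylamino)-1-methylethyl. Nothing available here bears on what lies behind this rise.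

The compounds shown leave open whether the dimethylamino group is what matters or whether the branched carbon frame that carries it plays a part, and a tert-butyl group on the same carbonyl carbon would separate the two. From the compounds shown here alone, it is also open how a carboxylic acid, a primary amine or a longer chain ending in dimethylamino would read at this position.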